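The source may report more compounds than this note shows. Statements on the series, on what has been measured and on what is new or still open speak of the compounds shown alone.

Of the compounds shown here, three built on one shared core have been measured in a functional assay on CHO cells for antagonist activity at prostaglandin E2 receptor EP3 subtype (Homo sapiens), read by cAMP accumulation, with a stated time of 30 min; a lower number here means a stronger inhibitor, a higher number a weaker inhibitor. Compound 1 `CC(C)C(/C=C1\NC(=O)NC1=O)c1ccc(-c2ccc3cccc(F)c3c2)[nH]c1=O` gives 87 nM. Compound 2 `CC(C)C(CC1NC(=O)NC1=O)c1ccc(-c2ccc3cccc(F)c3c2)[nH]c1=O` gives 31 nM, a change of a 2.8-fold lower number from compound 1 to compound 2 (0.45 log units; beyond the scatter). Compound 3 `CC(C)C(/C=C1/C(=O)NC(=O)N1C)c1ccc(-c2ccc3cccc(F)c3c2)[nH]c1=O` gives 11 nM, the lowest of the three numbers, reached by a 2.8-fold lower number from compound 2 to compound 3 (0.45 log units; beyond the scatter) and by a 7.9-fold lower number from compound 1 to compound 3 (0.90 log units; beyond the scatter). Compound 4 `CC(C)C(CC1C(=O)NC(=O)N1C)c1ccc(-c2ccc3cccc(F)c3c2)[nH]c1=O` has not yet been measured; it differs from compound 3 by a group of 9 heavy atoms (5 carbon, 2 nitrogen, 2 oxygen; one five-membered non-aromatic ring with 2 hetero atoms) in place of a group of 9 heavy atoms (5 carbon, 2 nitrogen, 2 oxygen; one five-membered non-aromatic ring with 2 hetero atoms), on a saturated chain carbon bound to an aromatic carbon and a saturated chain carbon. Going by the values given here, the only measured step of the same kind is a 2.8-fold lower number from compound 1 to compound 2 (0.45 log units; beyond the scatter), a modest lowering, so a similar modest lowering is expected in this assay from compound 3 to compound 4, though with a single precedent its size remains uncertain. Compound 4 is therefore estimated at 5.5 nM, within a range of 2 nM to 18 nM, which would mean a step of a 2.0-fold lower number from compound 3 to compound 4 (0.30 log units; within the scatter).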

Compound 4, half-maximal inhibitory concentration: 65 nM
Compound 4: middle estimate off by 12-fold (1.07 log units), on the low side; the measured number lies above the stated range.
By their numbers in this assay, from the lowest: compound 3; then compound 2; then compounds 4 and 1 (each within the scatter of the next).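

Removing one double bond from the group on this saturated chain carbon gave a 5.9-fold higher number from compound 3 to compound 4 (0.77 log units; beyond the scatter), the opposite direction to a 2.8-fold lower number from compound 1 to compound 2 (0.45 log units; beyond the scatter), so this change has no single direction across the two cores. The methyl on the ring nitrogen likewise reversed, with a 2.1-fold higher number from compound 2 to compound 4 (0.32 log units; beyond the scatter), and the effect of the methyl depends on the double bond: the same change on two cores in this assay, a 7.9-fold lower number (0.90 log units; beyond the scatter) from compound 1 to compound 3 and a 2.1-fold higher number (0.32 log units; beyond the scatter) from compound 2 to compound 4, 17-fold (1.22 log units) apart, beyond the scatter of two such steps Carrying both changes together gave a 1.3-fold lower number from compound 1 to compound 4 (0.13 log units; within the scatter).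

Going by these compounds, whether an ethyl on that ring nitrogen would follow compound 3 or compound 4 remains open, as does the effect of a carboxylic acid in place of the (3-methyl-2,5-dioxoimidazolidin-4-yl)methyl group.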